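One More Link in the Chain

The compounds below may be only part of what the source reports. "The series", "measured", "known", "first", "only" and "open" are said of these compounds alone.

Compound 2 `N#C/N=C1\N(CCCCCCOc2ccc(Cl)cc2)C(=O)CCN1c1ccncc1` gives 565 nM in a functional assay on DLD-1 cells (Homo sapiens) for cytotoxicity; a lower number here means a stronger inhibitor, a higher number a weaker inhibitor. Among the two measured compounds it holds the lowest number; its nearest neighbour, compound 1 `N#C/N=C1\N(CCCCCOc2ccc(Cl)cc2)C(=O)CCN1c1ccncc1`, gives 6740 nM in this assay. Within the data shown here, the only measured step is a 12-fold lower number from compound 1 to compound 2 (1.08 log units; beyond the scatter). Compound 3 `N#C/N=C1\N(CCCCCCCOc2ccc(Cl)cc2)C(=O)CCN1c1ccncc1` differs from compound 2 by (4-chlorophenoxy)methyl in place of 4-chlorophenoxy on a saturated chain carbon, six bonds along the chain from an amide-type nitrogen in a ring. The step from compound 1 to compound 2 bears directly on this change, since it is the same kind of alteration, its place five rather than six bonds along the chain from the amide-type nitrogen in the ring, and it was large. Whether a further step of the same kind carries the trend onward is not shown by any measured pair, so the expectation rests on that single step and is held cautious. Compound 3 is therefore expected to give a lower number than compound 2 in this assay, but by a smaller margin, an expected step of a 1.9-fold lower number from compound 2 to compound 3 (0.27 log units; within the scatter). The estimate for compound 3 is 300 nM, expected to fall between 80 nM and 1500 nM.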

Compound 3, half-maximal inhibitory concentration: 3200 nM
Estimate against measurement, compound 3: 11-fold (1.03 log units) below; the whole stated range lies below it.
By their numbers in this assay, from the lowest: compound 2; then compound 3; then compound 1.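

Adding one more link does not carry the earlier gain forward: in this assay, the same kind of change, made one bond further along the chain, reverses direction, giving (a 5.7-fold higher number from compound 2 to compound 3 (0.75 log units; beyond the scatter)) where the preceding step had given (a 12-fold lower number from compound 1 to compound 2 (1.08 log units; beyond the scatter)). Among these compounds, the effect of this change therefore depends on where along the chain it is made, a dependence that the single earlier step could not reveal. Compound 3 nevertheless keeps part of the advantage over the shorter chain (a 2.1-fold lower number from compound 1 to compound 3 (0.32 log units; beyond the scatter)), so among these three compounds the number does not move steadily with chain length, and compound 2 stands lowest, with its steps to both others beyond the scatter; nothing available explains why the direction turns at this point.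

The compounds shown leave open whether a longer chain than that of compound 3 would raise the number further, level off or lower it again. They also leave open whether the chain length of compound 2 would remain the best of the series if an amine or a carboxylic acid stood in place of the 4-chlorophenoxy group at the chain end.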